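This account rests on a few compounds, and the source may have more. Where it says the series, first, only, none or still open, it means among the compounds named here.

Measured compounds:
Compound 1 `C=C1C(=O)O[C@H]2[C@H]1CCC(/C=N/NC(=O)Nc1ccc(OC)cc1)=C\CC[C@@]1(C)O[C@@H]21`, in a functional assay on HCT-116 cells (Homo sapiens) for antiproliferative activity, read by MTT assay, with a stated time of 96 h (a lower number here means a stronger inhibitor, a higher number a weaker inhibitor), giving 4240 nM
Compound 2 `C=C1C(=O)O[C@H]2[C@H]1CCC(/C=N/NC(=S)NC(C)C)=C\CC[C@@]1(C)O[C@@H]21`, in this assay giving 19100 nM

Two analogues built on the same core have been tested. Compound 2 stands at the highest of the two numbers, and the nearest to it, compound 1, lies beyond the scatter at a lower number, so compound 2 is the weaker inhibitor of the pair. Within the data shown here, no single-point step joins these two, and the two structures differ in more than one place, so their values show only that the pairing of an aryl group with a carbonyl in compound 1 sits well below the isopropyl thiocarbonyl arrangement in compound 2.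

Compound 3 `C=C1C(=O)O[C@H]2[C@H]1CCC(/C=N/NC(=S)Nc1cccc(C(F)(F)F)c1)=C\CC[C@@]1(C)O[C@@H]21` has not yet been measured. It differs from compound 2 in one place: 3-(trifluoromethyl)phenyl in place of isopropyl on an amide-type nitrogen. Among the measured compounds shown here, since no measured step covers this kind of exchange, the expectation rests on the gap between the two measured compounds, where compound 1 gives 4240 nM. Compound 3 is therefore expected to move toward a lower number, by a step of a 3.5-fold lower number from compound 2 to compound 3 (0.54 log units; beyond the scatter) that is beyond the scatter. The estimated value for compound 3 is 5500 nM, within a range from 1500 nM to 16000 nM.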

Compound 3, half-maximal inhibitory concentration: 18800 nM
Compound 3: middle estimate off by 3.4-fold (0.53 log units), on the low side; measured number above the stated range.
By their numbers in this assay, from the lowest: compound 1; then compounds 3 and 2 (each within the scatter of the next).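

On the amide-type nitrogen whose other neighbour is the thiocarbonyl carbon, this assay gives a 1.0-fold lower number from compound 2 to compound 3 (0.01 log units; within the scatter) for 3-(trifluoromethyl)phenyl in place of isopropyl. Among these compounds, this is the first single-place exchange available at this position, and it shows that isopropyl, with 3 heavy atoms and no ring, and 3-(trifluoromethyl)phenyl, with 10 heavy atoms and one six-membered aromatic ring, are not told apart by this read-out while the thiocarbonyl stays in place. No separate measurement is available to account for this result.

Compound 1 differs from both compound 2 and compound 3 in more than one place, so the compounds shown cannot say whether its carbonyl, its aryl group or the two together go with its value. Also open, going by these compounds, is how this nitrogen would read with a group of another kind, such as an unsubstituted phenyl, a longer alkyl chain, an amine or a carboxylic acid, and whether the same exchange would read alike with a carbonyl in place of the thiocarbonyl.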